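From benzyl to ethenyl link: expected cytotoxicity of compound 3

This account rests on a few compounds, and the source may have more. Where it says the series, first, only, none or still open, it means among the compounds named here.

Of the compounds shown here, two have been tested for their effect on host cells. Compound 1 `CC1(Cc2ccc(C(F)(F)F)cc2)CC(S(=O)(=O)c2ccc(F)cc2)=C(c2ccc(/C(N)=N/O)cc2)O1` in an ADME assay on cells (Peritoneal macrophage, Mus musculus, strain Balb/c) for cytotoxicity, read by resazurin assay, with a stated time of 72 h (on this read-out higher numbers stand for lower toxicity in this test and lower numbers for higher toxicity in this test), gives 103000 nM. Compound 2 `CC1(Cc2ccc(-c3ccccc3)cc2F)CC(S(=O)(=O)c2ccc(F)cc2)=C(c2ccc(/C(N)=N/O)cc2)O1` in this assay gives 24500 nM. Going by the values given here, of these two numbers, the one for compound 1 is the higher, and the gap to compound 2 lies beyond the scatter of repeated measurements, so compound 1 stands as the less toxic of the pair in this test.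

Compound 3 `CC1(/C=C/c2ccc(C(F)(F)F)cc2)CC(S(=O)(=O)c2ccc(F)cc2)=C(c2ccc(/C(N)=N/O)cc2)O1` has not yet been measured. It differs from compound 1 in one place: 2-(4-(trifluoromethyl)phenyl)ethenyl in place of 4-(trifluoromethyl)benzyl on a saturated ring carbon. The ring bearing the trifluoromethyl group is kept; only the link to the saturated ring carbon changes, the benzyl giving way to an ethenyl with one double bond outside aromatic rings. Among the compounds with values here, no measured pair shows a step of this kind, so its size is open. Since the rest of compound 1, which gives 103000 nM, stays intact, a modest change is expected. The estimate for compound 3 in this assay is 80000 nM, with a range from 30000 nM to 200000 nM. The expected step of a 1.3-fold lower number from compound 1 to compound 3 (0.11 log units; within the scatter) is small, slightly downward and roughly within the scatter.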

Compound 3, half-maximal cytotoxic concentration: 43900 nM
Compound 3: the middle estimate sits 1.8-fold (0.26 log units) above what was measured, within the range that was stated.
By their numbers in this assay, from the lowest: compounds 2 and 3 (each within the scatter of the next); then compound 1.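

Going by these compounds alone, replacing 4-(trifluoromethyl)benzyl with 2-(4-(trifluoromethyl)phenyl)ethenyl on the saturated ring carbon gives a 2.3-fold lower number from compound 1 to compound 3 (0.37 log units; beyond the scatter) in this assay, the first step that can be read at this position. This read-out falls as toxicity in the test rises. The step therefore marks a modest move towards higher toxicity, and it comes from a change in the link alone: the ring bearing the trifluoromethyl group and the rest of the core of compound 1 are kept. The data therefore show that this test responds to the link itself, though no measurement at hand says what about the new link matters.

The compounds shown leave open whether a saturated ethyl link would give a number closer to that of the benzyl group or to that of the ethenyl group, and whether an ether oxygen or an amine in the link would fit either. They also leave open whether the same change of link would give a step of similar size with another group on the ring, such as a carboxylic acid or a phenyl group in place of trifluoromethyl.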